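Methyl for difluoroethyl on the aryl of compound 3

A few compounds are considered here, and "the series" means these few. Any claim that something is new, unique, unknown or untested is made for them only; others in the source may bear on it.

Measured so far in an ADME assay on microsomes from liver (Homo sapiens) for metabolic stability, read by LC-MS, using NADPH, with a stated time of 10 min, tested at 0.1 uM; a lower number here means slower removal, a higher number faster removal of the compound:
compound 1 `O=C(NCCCCc1ccccc1)c1cccc(C2SCC(=O)N2c2cccc(-c3c[nH]nn3)c2)c1`: 261 mL.min-1.g-1
compound 2 `C#Cc1cc(C(=O)NCCCCc2ccccc2)cc(C2SCC(=O)N2c2ccccc2OC)c1`: 1730 mL.min-1.g-1
compound 3 `CC(F)(F)c1cccc(N2C(=O)CSC2c2cccc(C(=O)NCCCCc3ccccc3)c2)c1`: 1750 mL.min-1.g-1

Compound 3 gives the highest number of the three in this assay. Compound 2 is the nearest to it, and the two values lie within the scatter of each other, so no order between them can be read. Compound 1 is the furthest away, with the step of a 6.7-fold higher number from compound 1 to compound 3 (0.83 log units; beyond the scatter), which is beyond the scatter and of modest size.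

Compound 4 `Cc1cccc(N2C(=O)CSC2c2cccc(C(=O)NCCCCc3ccccc3)c2)c1` differs from compound 3 by methyl in place of 1,1-difluoroethyl on an aromatic carbon. Among the compounds with values here, the only measured step at this same position is a 6.7-fold higher number from compound 1 to compound 3 (0.83 log units; beyond the scatter), and it concerns a ring group with hydrogen-bond donors and acceptors, not a methyl; no measured pair contains a methyl at this place. That step therefore gives the direction of a swap away from the triazolyl but says nothing direct about methyl against 1,1-difluoroethyl. Within the data shown here, with no closer precedent, the expectation for this assay is a step no larger than the scatter, with a slight lean toward a lower number.

Compound 4 is therefore estimated at 1300 mL.min-1.g-1 in this assay, within 550 mL.min-1.g-1 to 3200 mL.min-1.g-1, which means an expected step of a 1.3-fold lower number from compound 3 to compound 4 (0.13 log units; within the scatter).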

Compound 4, intrinsic clearance in microsomes: 2550 mL.min-1.g-1
Beside the measured number, compound 4's estimate is 2.0-fold (0.29 log units) below it; the measured number falls inside the stated range.
By their numbers in this assay, from the lowest: compound 1; then compounds 2, 3 and 4 (each within the scatter of the next).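

In this assay, methyl and 1,1-difluoroethyl cannot be told apart at this place, on an aromatic carbon meta to a large group: the swap gives a 1.5-fold higher number from compound 3 to compound 4 (0.16 log units; within the scatter), although the entering group has far fewer heavy atoms than the one it replaces. Compound 1 now stands apart from two compounds with a small non-ring group at this place, the new comparison being a 9.8-fold higher number from compound 1 to compound 4 (0.99 log units; beyond the scatter), alongside the earlier 6.7-fold higher number from compound 1 to compound 3 (0.83 log units; beyond the scatter); among these three compounds, only the 1H-1,2,3-triazol-4-yl goes with the low number. No available measurement bears on why the numbers fall this way.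

The compounds shown leave open whether the low number of compound 1 belongs to the triazole ring as such or would also appear with a simple amine, a carboxylic acid or another ring, such as pyridine, at this place. On these data alone, whether the same holds on other versions of the core also remains open, as a plain hydrogen or a longer alkyl chain here could fall near either end of the range.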